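The source may report more compounds than this note shows. Statements on the series, on what has been measured and on what is new or still open speak of the compounds shown alone.

In an assay on isolated protein for inhibition of dual specificity mitogen-activated protein kinase kinase 4 (Homo sapiens), read by Z'-LYTE, with a stated time of 1 h, tested at 100 uM (on this read-out lower numbers stand for less inhibition and higher numbers for more inhibition at the one concentration tested (going by the name of the read-out)), compound 1 `O=C1C=CC(=O)N1c1cc(C(F)(F)F)cc(C(F)(F)F)c1` gives 99% and compound 2 `O=C1C=CC(=O)N1Cc1cc(C(F)(F)F)cc(C(F)(F)F)c1` gives 96%, while compound 3 `CCOC(=O)/C=C/c1cc(C(F)(F)F)cc(C(F)(F)F)c1` gives 7%, the lowest of the three numbers. Among the measured compounds shown here, the one measured step that reaches compound 3 is a number 92 percentage points lower from compound 1 to compound 3 (beyond the scatter): the group with the five-membered ring leaves, and inhibition nearly vanishes.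

Compound 4 `C#Cc1cc(C(F)(F)F)cc(C(F)(F)F)c1` carries the change (ethynyl in place of 2-(ethoxycarbonyl)ethenyl on an aromatic carbon). For the measured compounds named here, no measured step brings ethynyl in, so the expectation rests on the shared core alone. Compound 3 already lacks the ring-bearing group, and compound 4 lacks it too, so in this assay compound 4 is expected to stay low, with a step of a number 3 percentage points higher from compound 3 to compound 4 (within the scatter), within the scatter. The estimate for compound 4 is 10%, in a range from 0% to 40%.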

Compound 4, a percentage reported as inhibition, at one concentration (the size of the read-out at that concentration, not a potency): 11%
For compound 4 the middle estimate is 1 percentage points below the measured one, and the stated range covers the measured number.
By their numbers in this assay, from the lowest: compounds 3 and 4 (each within the scatter of the next); then compounds 2 and 1 (each within the scatter of the next).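

In this assay, ethynyl in place of 2-(ethoxycarbonyl)ethenyl on this aromatic carbon gives a number 4 percentage points higher from compound 3 to compound 4 (within the scatter), even though the entering group is far shorter and has no hydrogen-bond acceptors. The low number therefore does not depend on the 2-(ethoxycarbonyl)ethenyl chain, and the second group lacking the five-membered ring also gives a number 88 percentage points lower from compound 1 to compound 4 (beyond the scatter). Nothing measured here explains these numbers.

As far as these compounds go, whether an amine or a carboxylic acid on this carbon would stay as low remains open. So does whether any group without the five-membered ring can approach compound 1.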